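The compounds below may be only part of what the source reports. "The series", "measured", "known", "first", "only" and "open" are said of these compounds alone.

Compound 1 `C[C@@H]1CN(c2sc(C(F)(F)F)nc2-c2nc3ccccc3[nH]2)CCN1C(=O)Cn1ccc(C(=O)O)n1` gives 5570 nM in a functional assay on Venous blood for antagonist activity at C-X-C chemokine receptor type 3 (Homo sapiens), read by flow cytometry, with a stated time of 30 min, in the presence of a further agent that is not named here; a higher number here means a weaker inhibitor, a lower number a stronger inhibitor.
Compound 2 `COC1CCN(CC(=O)N2CCN(c3sc(C(F)(F)F)nc3-c3nc4ccccc4[nH]3)C[C@H]2C)C1` gives 3380 nM in this assay.
Compound 3 `C[C@@H]1CN(c2sc(C(F)(F)F)nc2-c2nc3ccccc3[nH]2)CCN1C(=O)CN1C(=O)OC[C@@H]1c1ccccc1` gives 1380 nM in this assay.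

The three compounds share one core and differ only in the group that sits on a saturated chain carbon bound to a carbonyl carbon. Compound 3 stands lowest of the three numbers, that is, it is the strongest inhibitor here: the step of a 4.0-fold lower number from compound 1 to compound 3 (0.61 log units; beyond the scatter) and the step of a 2.4-fold lower number from compound 2 to compound 3 (0.39 log units; beyond the scatter) both lie beyond the scatter, while the step of a 1.6-fold lower number from compound 1 to compound 2 (0.22 log units; within the scatter) does not.

Compound 4 `C[C@@H]1CN(c2sc(C(F)(F)F)nc2-c2nc3ccccc3[nH]2)CCN1C(=O)Cn1cccn1` differs from compound 3 in one place: 1H-pyrazol-1-yl in place of 2-oxo-4-phenyl-1,3-oxazolidin-3-yl on a saturated chain carbon bound to a carbonyl carbon. Within the data shown here, no measured step joins these two end groups directly. Among the measured compounds shown here, the step that bears most on it is a 4.0-fold lower number from compound 1 to compound 3 (0.61 log units; beyond the scatter), since compound 1 carries a pyrazolyl group that differs from the one entering in compound 4 only by its carboxy group. Going the other way, from the oxazolidinone group back to a pyrazolyl group, the number is expected to rise again, probably to near the value of compound 1, with wide uncertainty. The expected step is a 2.9-fold higher number from compound 3 to compound 4 (0.46 log units; beyond the scatter). Compound 4 is thus estimated at 4000 nM, with a likely range from 1500 nM to 12000 nM.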

Compound 4, half-maximal inhibitory concentration: 191 nM
Compound 4: the middle estimate sits 21-fold (1.32 log units) above what was measured; the whole stated range lies above it.
By their numbers in this assay, from the lowest: compound 4; then compound 3; then compounds 2 and 1 (each within the scatter of the next).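

Hydrogen in place of carboxy on an aromatic carbon gives a 29-fold lower number from compound 1 to compound 4 (1.46 log units; beyond the scatter) in this assay and is the only change between the two, so the high number of compound 1 goes with its carboxy group and not with the pyrazolyl ring that carries it. The plain 1H-pyrazol-1-yl, with fewer heavy atoms than 2-oxo-4-phenyl-1,3-oxazolidin-3-yl, also outdoes both other end groups on the saturated chain carbon bound to a carbonyl carbon, with a 7.2-fold lower number from compound 3 to compound 4 (0.86 log units; beyond the scatter) and an 18-fold lower number from compound 2 to compound 4 (1.25 log units; beyond the scatter) making it the strongest inhibitor of the four, though an aromatic ring alone is not enough, as compound 1 shows. No measured evidence is available to explain these differences.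

The compounds shown leave open whether a small group such as methyl or methoxy on the pyrazolyl ring keeps the number low, or whether only the carboxy group raises it. They also leave open whether another aromatic ring on the chain, such as imidazol-1-yl or 1,2,4-triazol-1-yl, would match the 1H-pyrazol-1-yl.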